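A few compounds are considered here, and "the series" means these few. Any claim that something is new, unique, unknown or untested is made for them only; others in the source may bear on it.

Working notes on the series. Of the compounds shown here, two have been measured in a functional assay on Umbilical vein for antagonist activity at B1 bradykinin receptor (Homo sapiens), using Schild analysis, with a stated time of 30 min (a higher number here means a more potent compound, by a factor of ten per unit of this negative logarithm, a lower number a less potent compound), so far. Compound 1, `COc1cc(C)c(S(=O)(=O)N(C)CCOCC(=O)N2CCN([C@@H]3CN4CCC3CC4)CC2)c(C)c1`, gives 8.1 in this assay. Compound 2, `COc1cc(C)c(S(=O)(=O)N(C)CCOCC(=O)N2CCC(N3CCN(C(C)C)CC3)CC2)c(C)c1`, gives 8.5 in this assay. Compound 1 thus stands at the lower of the two numbers, and the gap to compound 2 lies beyond the usual scatter of the measurement.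

The next compound, compound 3, `CCN1CCC(N2CCN(C(=O)COCCN(C)S(=O)(=O)c3c(C)cc(OC)cc3C)CC2)CC1`, has not yet been measured. Relative to compound 1 the change is a group of 8 heavy atoms (7 carbon, 1 nitrogen; one six-membered non-aromatic ring with 1 hetero atom) in place of a group of 8 heavy atoms (7 carbon, 1 nitrogen; 2 six-membered non-aromatic rings with 1 hetero atom each), on an amine nitrogen in a ring. The group that enters is a 1-ethylpiperidin-4-yl on the amine nitrogen in the ring, so the same count of heavy atoms is kept while two six-membered non-aromatic rings are replaced by one.

For the measured compounds named here, no step between two measured compounds matches this change, so the expectation rests on the two values alone. Compound 3 is expected to give 8.4 in this assay, with an estimated range from 7.9 to 8.9. The expected step of a number 0.30 log units higher from compound 1 to compound 3 (within the scatter) is upward but small, of a size that could still fall within the usual scatter.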

Compound 3, negative logarithm of the antagonist equilibrium constant: 8.8
Estimate against measurement, compound 3: 0.40 log units below, within the range that was stated.
By their numbers in this assay, from the lowest: compound 1; then compounds 2 and 3 (each within the scatter of the next).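

In this assay, this place on the ring amine nitrogen now has its first readable step: putting 1-ethylpiperidin-4-yl in place of the group with 2 six-membered non-aromatic rings gives a number 0.70 log units higher from compound 1 to compound 3 (beyond the scatter). The exchange keeps the heavy-atom count, the hydrogen-bond donor and acceptor counts and the absence of net charge, so this place responds to a change that leaves all of these counts as they were, while one ring and the defined stereocentre are lost. A single step cannot separate the loss of the ring from the loss of the stereocentre, and no measurement at hand bears on what lies behind the step.

Still open, going by these compounds, is whether compound 3, at 8.8, depends on its ethyl group, since a 1-methylpiperidin-4-yl, a 1-propylpiperidin-4-yl or a piperidin-4-yl with a free ring amine at the same place would test this. The opposite configuration at the stereocentre of compound 1 is also absent from the compounds shown, so the part that this stereocentre plays in the value of compound 1, 8.1, remains open.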